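This account rests on a few compounds, and the source may have more. Where it says the series, first, only, none or still open, it means among the compounds named here.

Compound 1 `CN1CCCN(CCn2ccc3ccc(F)cc32)CC1`: in an assay on HEK293 cells for binding affinity to 5-hydroxytryptamine receptor 7 (Homo sapiens), read by radioligand binding, tested at 1 uM (on this read-out lower numbers stand for less inhibition and higher numbers for more inhibition at the one concentration tested (going by the name of the read-out)), compound 1 gives 60%.
Compound 2 `CN1CCCN(CCn2ccc3ccc(OCc4ccccc4)cc32)CC1`: compound 2 gives 28%.
Compound 3 `C=C(C)c1ccc2ccn(CCN3CCCN(C)CC3)c2c1`: compound 3 gives 72%.

Compound 3 stands highest of the three numbers in this assay. Its nearest neighbour is compound 1, with a number 12 percentage points higher from compound 1 to compound 3 (beyond the scatter), and the furthest is compound 2, with a number 44 percentage points higher from compound 2 to compound 3 (beyond the scatter).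

Compound 4 `CN1CCCN(CCn2ccc3ccc(-c4ccsc4)cc32)CC1` is the unmeasured one. It differs from compound 3 in one place: thiophen-3-yl in place of 1-methylethenyl on an aromatic carbon. All three measured steps sit at this same aromatic carbon, so all bear on the change. The step of a number 32 percentage points lower from compound 1 to compound 2 (beyond the scatter) was large and downward when a group carrying an aromatic ring entered; the step of a number 12 percentage points higher from compound 1 to compound 3 (beyond the scatter) was modest and upward with 1-methylethenyl. Thiophen-3-yl again brings in an aromatic ring, though a smaller one attached directly, and no step tests exactly that. A downward move of moderate size is therefore expected for compound 4 in this assay, that is a number 17 percentage points lower from compound 3 to compound 4 (beyond the scatter). Compound 4 is estimated at 55%, within a range from 30% to 78%.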

Compound 4, a percentage reported as inhibition, at one concentration (the size of the read-out at that concentration, not a potency): 68%
Beside the measured number, compound 4's estimate is 13 percentage points below it; measured number inside the range.
By their numbers in this assay, from the lowest: compound 2; then compounds 1, 4 and 3 (each within the scatter of the next, the first and the last beyond it).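

In this assay, an aromatic ring on this aromatic carbon does not by itself bring the number down: thiophen-3-yl in place of 1-methylethenyl gives a number 4 percentage points lower from compound 3 to compound 4 (within the scatter), and thiophen-3-yl in place of fluoro gives a number 8 percentage points higher from compound 1 to compound 4 (within the scatter). Among these four compounds the low number therefore goes with benzyloxy alone and not with aromatic substituents as a class, as thiophen-3-yl in place of benzyloxy gives a number 40 percentage points higher from compound 2 to compound 4 (beyond the scatter). Nothing available explains why benzyloxy and thiophen-3-yl part ways here.

As far as these compounds go, what a directly attached phenyl or a phenoxy group would give at this carbon remains open, and so does whether the link or the ring of benzyloxy matters more. From the compounds shown here alone, how a substituent carrying an amine or a carboxylic acid would read here is equally open.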